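Adding a Methyl to a Thromboxane Receptor Antagonist Urea

The source may report more compounds than this note shows. Statements on the series, on what has been measured and on what is new or still open speak of the compounds shown alone.

Compound 1 `CC(C)NC(=O)NS(=O)(=O)c1cc(C#N)ccc1Oc1ccc(F)cc1` is a sulfonylurea built around a diaryl ether core; in a functional assay on HEK293 cells for antagonist activity at thromboxane A2 receptor (Homo sapiens), read by fluorescence and calcium flux (on this read-out higher numbers stand for weaker inhibition and lower numbers for stronger inhibition), compound 1 gives 9300 nM. Compound 2 `CC(C)(C)NC(=O)NS(=O)(=O)c1cc(C#N)ccc1Oc1ccc(F)cc1` differs from compound 1 by methyl in place of hydrogen on a saturated chain carbon bound to an amide-type nitrogen and two saturated chain carbons; in this assay compound 2 gives 3890 nM, so a 2.4-fold lower number from compound 1 to compound 2 (0.38 log units; beyond the scatter). Compound 3 `CC(C)NC(=O)NS(=O)(=O)c1cc(C#N)ccc1Oc1ccc(Br)cc1` differs from compound 1 by bromo in place of fluoro on an aromatic carbon; in this assay compound 3 gives 9130 nM, and a 1.0-fold lower number from compound 1 to compound 3 (0.01 log units; within the scatter). Compound 4 `CC(C)(C)NC(=O)NS(=O)(=O)c1cc(C#N)ccc1Oc1ccc(Br)cc1` carries both changes at once. It differs from compound 3 by methyl in place of hydrogen on a saturated chain carbon bound to an amide-type nitrogen and two saturated chain carbons, the same change that leads from compound 1 to compound 2, and the place of the change is described in the same words in both pairs. Because a 2.4-fold lower number from compound 1 to compound 2 (0.38 log units; beyond the scatter), a step of about that size is expected in this assay, namely a 2.4-fold lower number from compound 3 to compound 4 (0.38 log units; beyond the scatter). Compound 4 is therefore estimated at 3800 nM, with a likely range from 1800 nM to 8000 nM.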

Compound 4, half-maximal inhibitory concentration: 5310 nM
For compound 4 the middle estimate is 1.4-fold (0.15 log units) below the measured one, and the stated range covers the measured number.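

The methyl step on the bromo core is a 1.7-fold lower number from compound 3 to compound 4 (0.24 log units; within the scatter), and it sits close to the same step on the fluoro core: the same change on two cores in this assay, a 2.4-fold lower number (0.38 log units; beyond the scatter) from compound 1 to compound 2 and a 1.7-fold lower number (0.24 log units; within the scatter) from compound 3 to compound 4, 1.4-fold (0.14 log units) apart, within the scatter of two such steps Swapping fluoro for bromo on the tert-butyl compounds gives a 1.4-fold higher number from compound 2 to compound 4 (0.14 log units; within the scatter), which also matches the same swap on the isopropyl compounds: the same change on two cores in this assay, a 1.0-fold lower number (0.01 log units; within the scatter) from compound 1 to compound 3 and a 1.4-fold higher number (0.14 log units; within the scatter) from compound 2 to compound 4, 1.4-fold (0.14 log units) apart, within the scatter of two such steps In this assay both changes therefore carried from one core to the other as far as these four compounds can tell, but the methyl step on the bromo core cannot itself be told from repeat scatter, and two pairs per change show no general rule.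

As far as these compounds go, it remains open how a cyclohexyl group in place of tert-butyl would read in this assay. The same holds for a chloro or methoxy group in place of the bromo.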